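Triazole-linked cinnamic acids: swapping the aryl substituent

A few compounds are considered here, and "the series" means these few. Any claim that something is new, unique, unknown or untested is made for them only; others in the source may bear on it.

The measured compounds:
compound 1, `COc1ccc(-n2cc(COc3c(/C=C\C(=O)O)ccc(OC)c3CC=C(C)C)nn2)cc1`, "not determined" (no result reported)
compound 2, `COc1ccccc1-n1cc(COc2c(/C=C\C(=O)O)ccc(OC)c2CC=C(C)C)nn1`, 12200 nM

Two compounds of this series have been put through a functional assay on COLO 205 cells (Homo sapiens) for cytotoxicity, read by MTT assay, with a stated time of 24 h; on this read-out lower numbers stand for stronger inhibition and higher numbers for weaker inhibition. For compound 1 no result is reported, so the read-out for it is "not determined" (no result reported). Among the compounds with values here, compound 2, whose structure stands beside it in the list of measured compounds, gives 12200 nM in this assay; that is the only number the series offers as a foothold, and with no step between two measured compounds available, nothing can be said about how much any single change moves the read-out.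

The next compound, compound 3, `COc1ccc(/C=C\C(=O)O)c(OCc2cn(-c3cccc(C#N)c3)nn2)c1CC=C(C)C`, is to be measured in this assay. It differs from compound 1 in one place: 3-cyanophenyl in place of 4-methoxyphenyl on an aromatic nitrogen. Compound 1 carries no number. Within the data shown here, the step from compound 1 to compound 3 therefore cannot be sized from the data, and the only anchor is compound 2 at 12200 nM. The expectation is therefore modest and wide: compound 3 is estimated to land at 10000 nM, within a range of 3000 nM to 40000 nM, with no direction claimed beyond the scatter.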

Compound 3, half-maximal inhibitory concentration: 26800 nM
The estimate for compound 3 lay 2.7-fold (0.43 log units) below the measured number; measured number inside the range.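

In this assay, the aryl group on an aromatic nitrogen of the five-membered aromatic ring now has its first readable step: 3-cyanophenyl in place of 2-methoxyphenyl gives a 2.2-fold higher number from compound 2 to compound 3 (0.34 log units; beyond the scatter). The read-out at this position therefore responds to the choice of aryl group, modestly but beyond the scatter, and this change moves it towards weaker inhibition, whereas the step from 4-methoxyphenyl to 3-cyanophenyl cannot be read, as compound 1 carries no number. Nothing in the data shown accounts for the size or direction of this step.

This single step exchanges both the substituent and the place it occupies on the phenyl ring, so the compounds shown cannot separate the contribution of the nitrile from that of its placement. They also leave open how the read-out would respond to a plain phenyl, a chlorophenyl or an aminophenyl on the same nitrogen, and whether any aryl group here would give a number much lower than those of compound 2 and compound 3.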